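Phenyl in Place of Dimethylphenyl: An Expected Step

The source may report more compounds than this note shows. Statements on the series, on what has been measured and on what is new or still open speak of the compounds shown alone.

Of the compounds shown here, two have been tested in an assay on HEK-293T cells for activation of Bile acid receptor (Homo sapiens), read by a luciferase reporter, with a stated time of 14 h; a higher number here means that more compound is needed for the effect, a lower number that less compound is needed. Compound 1 `CC(C)c1onc(-c2ccccc2)c1COc1ccc(CCCCC(=O)O)cc1` reaches only a limit of the assay, > 30000 nM, and therefore gives no number. Among the compounds with values here, compound 2 `Cc1cccc(C)c1-c1noc(C(C)C)c1COc1ccc(CCCC(=O)O)cc1` gives 7700 nM in this assay, the only numerical value so far. Compound 3 `CC(C)c1onc(-c2ccccc2)c1COc1ccc(CCCC(=O)O)cc1` differs from compound 2 by phenyl in place of 2,6-dimethylphenyl on an aromatic carbon. Within the data shown here, no measured pair shows this change, so the expected step rests on no direct precedent. Compound 3 is expected to need more compound, at about 25000 nM, with a range from 8000 nM to 60000 nM. The expected step of a 3.2-fold higher number from compound 2 to compound 3 (0.51 log units; beyond the scatter) is modest, and a limit rather than a number remains possible.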

Compound 3, half-maximal effective concentration: 31000 nM
For compound 3 the middle estimate is 1.2-fold (0.09 log units) below the measured one, and the stated range covers the measured number.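

In this assay, within the data shown here, the change from 2,6-dimethylphenyl to phenyl gives a 4.0-fold higher number from compound 2 to compound 3 (0.60 log units; beyond the scatter), the first direct reading at this position on the shared core: the compound bearing the two methyl groups needs less compound for the effect. The step involving compound 1 cannot be read because the value of compound 1 is a limit and not a number: the limit of > 30000 nM in this assay, at which 1 of the 3 values shown sits.

On these data alone, what a 2,6-dichlorophenyl group would give at this position remains open. So does the effect of an amide in place of the carboxylic acid.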